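Trifluoromethoxy on the benzyl arm of compound 1

This account rests on a few compounds, and the source may have more. Where it says the series, first, only, none or still open, it means among the compounds named here.

Among the measured compounds shown here, compound 1 `COc1cccc(OC)c1C1CCCC(=O)N1Cc1ccccc1` is the reference: in a functional assay on CHO cells for antagonist activity at Orexin receptor type 2 (Homo sapiens), read by FLIPR and calcium flux (a higher number here means a weaker inhibitor, a lower number a stronger inhibitor), compound 1 gives 416 nM, the only number among the two results. For compound 2 `COc1cccc(OC)c1C1CCCC(=O)N1c1ccccc1` this assay reports only a limit, > 10000 nM. That comparison shows an at least 24-fold higher number from compound 1 to compound 2 (1.38 log units; beyond the scatter). Compound 3 `COc1cccc(OC)c1C1CCCC(=O)N1Cc1cccc(OC(F)(F)F)c1` differs from compound 1 by trifluoromethoxy in place of hydrogen on an aromatic carbon; it keeps the benzyl, so the measured step, which swaps benzyl for phenyl, does not bear on it. For the measured compounds named here, no measured step guides the size or direction here, so a change within the scatter is expected: a 1.4-fold lower number from compound 1 to compound 3 (0.14 log units; within the scatter). Compound 3 is therefore estimated at 300 nM, between 60 nM and 1500 nM.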

Compound 3, half-maximal inhibitory concentration: 94 nM
Beside the measured number, compound 3's estimate is 3.2-fold (0.50 log units) above it, and the stated range covers the measured number.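

Trifluoromethoxy in place of hydrogen on this aromatic carbon gives, in this assay, a 4.4-fold lower number from compound 1 to compound 3 (0.65 log units; beyond the scatter), so a stronger inhibitor. The earlier pair showed only that swapping the benzyl for phenyl costs activity, whereas this step shows that the benzyl arm can carry an added group and gain activity. Nothing shown here gives a measured reason for this gain.

From the compounds shown here alone, it remains open whether a fluorine or an amine on the same carbon would do the same. Going by these compounds, it is also open whether trifluoromethoxy would give a similar step on another carbon of that aromatic ring.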